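This account rests on a few compounds, and the source may have more. Where it says the series, first, only, none or still open, it means among the compounds named here.

Three compounds with a shared core carry a long chain ending in a positively charged ring group, and all were tested in an assay on LX2 cells for inhibition of COL1A1 promoter (Homo sapiens), read by a luciferase reporter, with a stated time of 24 h, tested at 50 uM; on this read-out lower numbers stand for a weaker effect and higher numbers for a stronger effect at the one concentration tested. Compound 1, `Cc1cc(-n2cc(C(=O)Nc3cc(F)cc(F)c3)c(=O)c3ccc(N(C)C)nc32)ccc1OCCCCCCC[N+]12CCN(CC1)CC2`, gives 20.8%. Compound 2, `Cc1cc(OCCCCCCC[N+]2(C)CCCC2)cc(-n2cc(C(=O)Nc3cc(F)cc(F)c3)c(=O)c3ccc(N(C)C)nc32)c1`, gives 35.4%. Compound 3, `Cc1cc(OCCCCCCC[n+]2ccccc2)cc(-n2cc(C(=O)Nc3cc(F)cc(F)c3)c(=O)c3ccc(N(C)C)nc32)c1`, gives 61%. Compound 1 thus stands lowest of the three, with compound 2 nearest to it and compound 3 furthest away. For the measured compounds named here, the one measured step, a number 25.6 percentage points higher from compound 2 to compound 3 (beyond the scatter), swaps the ring at the chain end.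

Compound 4, `Cc1cc(-n2cc(C(=O)Nc3cc(F)cc(F)c3)c(=O)c3ccc(N(C)C)nc32)ccc1OCCCCCCC[N+]1(C)CCN(C)CC1`, is made from compound 1 by the change (a group of 8 heavy atoms (6 carbon, 2 nitrogen; one six-membered non-aromatic ring with 2 hetero atoms) in place of a group of 8 heavy atoms (6 carbon, 2 nitrogen; 2 six-membered non-aromatic rings with 2 hetero atoms each), on a saturated chain carbon, seven bonds along the chain from an oxygen on an aromatic ring). The measured step from compound 2 to compound 3 changes a different pair of ring groups than this one, so it says nothing direct about the step at hand. Both compounds 1 and 4 keep a charged ring with the same count of atoms, so in this assay little movement beyond the scatter is expected, a number 6.2 percentage points higher from compound 1 to compound 4 (within the scatter). Compound 4 is estimated at 27%, within a range from 10% to 48%.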

Compound 4, a percentage reported as inhibition, at one concentration (the size of the read-out at that concentration, not a potency): 32%
For compound 4 the middle estimate is 5 percentage points below the measured one; the range from low to high includes it.
By their numbers in this assay, from the lowest: compound 1; then compounds 4 and 2 (each within the scatter of the next); then compound 3.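

At the chain end, seven bonds along the chain from an oxygen on an aromatic ring, the group with one six-membered non-aromatic ring in place of the group with 2 such rings gives a number 11.2 percentage points higher from compound 1 to compound 4 (beyond the scatter) in this assay. This shows that the read-out at this position can shift even when the heavy atoms, the hydrogen-bond acceptor count and the net charge of the end group stay the same, whereas the step between compound 2 and compound 3 exchanged a five-membered non-aromatic ring for a six-membered aromatic one. Nothing available explains this shift.

From the compounds shown here alone, it remains open how a trimethylammonium group or a charged morpholine ring at this chain end would compare on the core of compound 1. A shorter or longer chain carrying the end group of compound 4 also remains untested in the compounds shown here.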